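The source may report more compounds than this note shows. Statements on the series, on what has been measured and on what is new or still open speak of the compounds shown alone.

Measured compounds:
Compound 1 `CN(C(=O)NC(=O)c1ccc(Cl)cc1Cl)c1nc(C(F)(F)F)c(C(=O)N/N=C/c2ccc(C(F)(F)F)cc2)s1`: in a functional assay on A549 cells (Homo sapiens) for inhibition, read by MTT assay, with a stated time of 72 h (a higher number here means a weaker inhibitor, a lower number a stronger inhibitor), compound 1 gives 9.4 ug/mL.
Compound 2 `CN(C(=O)NC(=O)c1ccc(F)c(F)c1)c1nc(C(F)(F)F)c(C(=O)N/N=C/c2ccccc2C(F)(F)F)s1`: in this assay compound 2 gives 6.96 ug/mL.
Compound 3 `CN(C(=O)NC(=O)c1ccc(Cl)cc1Cl)c1nc(C(F)(F)F)c(C(=O)N/N=C/c2ccccc2C(F)(F)F)s1`: in this assay compound 3 gives 15.3 ug/mL.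

Compound 3 carries the highest of the three numbers, though a 1.6-fold higher number from compound 1 to compound 3 (0.21 log units; within the scatter) lies within the scatter, and only a 2.2-fold higher number from compound 2 to compound 3 (0.34 log units; beyond the scatter) stands beyond it. Compound 4 `CN(C(=O)NC(=O)c1c(F)cccc1F)c1nc(C(F)(F)F)c(C(=O)N/N=C/c2ccccc2C(F)(F)F)s1` is the next member of this series. Relative to compound 3 the change is 2,6-difluorophenyl in place of 2,4-dichlorophenyl on a carbonyl carbon. Among the measured compounds shown here, of the measured steps only the one from compound 2 to compound 3 touches the same position, and it showed that exchanging a difluorophenyl for a dichlorophenyl on that carbonyl carbon raised the number modestly. Compound 4 moves back to a difluorophenyl, although with a different substitution pattern, so a modest lowering of the number, possibly no further than the scatter, is what the data support for this assay. The estimated step is a 1.5-fold lower number from compound 3 to compound 4 (0.18 log units; within the scatter). Compound 4 is therefore expected to give about 10 ug/mL, within a range from 5 ug/mL to 20 ug/mL.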

Compound 4, half-maximal inhibitory concentration: 17.9 ug/mL
Compound 4: middle estimate off by 1.8-fold (0.25 log units), on the low side; the range from low to high includes it.
By their numbers in this assay, from the lowest: compounds 2, 1, 3 and 4 (each within the scatter of the next, the first and the last beyond it).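

With the halogen held as fluorine, moving from 3,4-difluorophenyl to 2,6-difluorophenyl on the carbonyl carbon gives, in this assay, a 2.6-fold higher number from compound 2 to compound 4 (0.41 log units; beyond the scatter), so a difluorophenyl at this position does not by itself bring the lower number of compound 2 and the placing of the fluorines matters here. Exchanging 2,4-dichlorophenyl for 2,6-difluorophenyl gives a 1.2-fold higher number from compound 3 to compound 4 (0.07 log units; within the scatter), which leaves compound 3 and compound 4 indistinguishable even though both the halogen and its placing differ. Nothing available here explains these differences.

Going by these compounds, a 3,4-dichlorophenyl or a 2,6-dichlorophenyl on that carbonyl carbon would help separate the kind of halogen from its placing, and that comparison remains open. Also open, on these data alone, is how a phenyl ring carrying a methoxy group or an amine would read at this position.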